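Pyrimidinyl for thiazolyl on the sulfonamide: outlook for compound 4

A few compounds are considered here, and "the series" means these few. Any claim that something is new, unique, unknown or untested is made for them only; others in the source may bear on it.

Measured so far:
compound 1 `O=c1oc2ccccc2c(Cl)c1/C=N/c1ccc(S(=O)(=O)Nc2nccs2)cc1` gives 300 nM in a functional assay on B16-F10 cells (Mus musculus) for cytotoxicity, read by CCK-8 assay, with a stated time of 48 h; a higher number here means a weaker inhibitor, a lower number a stronger inhibitor.
compound 2 `Cc1cc(C)nc(NS(=O)(=O)c2ccc(/N=C/c3c(Cl)c4ccccc4oc3=O)cc2)n1` gives 170 nM in this assay.
compound 3 `CC(C)(C)c1cc(C(C)(C)C)c2oc(=O)c(/C=N/c3ccc(S(=O)(=O)Nc4nccs4)cc3)c(Cl)c2c1` gives 160 nM in this assay.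

Compound 3 holds the lowest of the three numbers, but its gaps to compound 2 and to compound 1 both lie within the scatter, so no order among the three is claimed. Compound 4 `Cc1cc(C)nc(NS(=O)(=O)c2ccc(/N=C/c3c(Cl)c4cc(C(C)(C)C)cc(C(C)(C)C)c4oc3=O)cc2)n1` differs from compound 3 by 4,6-dimethylpyrimidin-2-yl in place of 1,3-thiazol-2-yl on a sulfonamide nitrogen. For the measured compounds named here, the one measured step that bears on this, a 1.8-fold lower number from compound 1 to compound 2 (0.25 log units; within the scatter), is the same exchange on the core of compound 1 and stayed within the scatter. A step of similar small size, or none beyond the scatter, is expected here. Compound 4 is therefore expected at 120 nM, with a range of 50 nM to 300 nM. The expected step is a 1.3-fold lower number from compound 3 to compound 4 (0.12 log units; within the scatter).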

Compound 4, half-maximal inhibitory concentration: 220 nM
Compound 4: middle estimate off by 1.8-fold (0.26 log units), on the low side; the range from low to high includes it.
By their numbers in this assay, from the lowest: compounds 3, 2, 4 and 1 (each within the scatter of the next).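

With the second core, the exchange on the sulfonamide nitrogen now reads twice: a 1.4-fold higher number from compound 3 to compound 4 (0.14 log units; within the scatter) in this assay. The two readings of the same change cannot be told apart: the same change on two cores in this assay, a 1.8-fold lower number (0.25 log units; within the scatter) from compound 1 to compound 2 and a 1.4-fold higher number (0.14 log units; within the scatter) from compound 3 to compound 4, 2.4-fold (0.38 log units) apart, within the scatter of two such steps. No direction can therefore be given to 4,6-dimethylpyrimidin-2-yl in place of 1,3-thiazol-2-yl on either core, and both groups are carried at this position with no step beyond the scatter.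

Still open, on these data alone, is whether any group on this nitrogen gives a step beyond the scatter, for instance an open alkyl chain or a carboxylic acid in place of the aromatic ring.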